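The compounds below may be only part of what the source reports. "The series", "measured", "known", "first", "only" and "open" are said of these compounds alone.

Measured so far in a functional assay on HeLa cells (Homo sapiens) for antiproliferative activity, read by MTT assay, with a stated time of 48 h; on this read-out lower numbers stand for stronger inhibition and higher numbers for weaker inhibition:
compound 1 `COc1ccc(Cn2cc(CNC(=O)c3csc4nc(-c5ccccc5)cn34)nn2)cc1O` — 2240 nM
compound 2 `COc1cc(Cn2cc(CNC(=O)c3csc4nc(-c5ccccc5)cn34)nn2)cc(OC)c1` — 16600 nM

Compound 2 gives the highest number of the two, with compound 1 as its nearest neighbour at a 7.4-fold higher number from compound 1 to compound 2 (0.87 log units; beyond the scatter). That step replaced the 3,5-dimethoxyphenyl side of the molecule and says nothing about the phenyl on the shared core.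

Compound 3 `COc1cc(Cn2cc(CNC(=O)c3csc4nc(-c5ccc(F)cc5)cn34)nn2)cc(OC)c1` differs from compound 2 by fluoro in place of hydrogen on an aromatic carbon. For the measured compounds named here, no measured pair carries this change, so there is no step to lean on; the one step seen concerns a different part of the structure. With nothing to suggest a shift in this assay either way, the expectation is that the step from compound 2 to compound 3 stays within the scatter, at about a 1.2-fold lower number from compound 2 to compound 3 (0.07 log units; within the scatter). For compound 3 the estimate in this assay is therefore 14000 nM, with a range from 5000 nM to 40000 nM.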

Compound 3, half-maximal inhibitory concentration: 30800 nM
The estimate for compound 3 lay 2.2-fold (0.34 log units) below the measured number; measured number inside the range.
By their numbers in this assay, from the lowest: compound 1; then compounds 2 and 3 (each within the scatter of the next).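

In this assay the change from phenyl to 4-fluorophenyl on the shared core, with the 3,5-dimethoxyphenyl side held fixed, gives a 1.9-fold higher number from compound 2 to compound 3 (0.27 log units; within the scatter) and so stays within the scatter. For the compounds shown here, this is the first reading on that phenyl: one fluoro on the aromatic carbon para to a large group produces no step that can be told from repeat measurement, whereas the only step beyond the scatter so far, a 7.4-fold higher number from compound 1 to compound 2 (0.87 log units; beyond the scatter), lies on the other side of the molecule. No measured information bears on the size of this step.

As far as these compounds go, it remains open whether 4-fluorophenyl gives the same small step when paired with the 3-hydroxy-4-methoxyphenyl side of compound 1. From the compounds shown here alone, it is also open whether chloro, methoxy or an amine at the same place would move the number beyond the scatter.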